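Side-chain variation on a quinazoline alpha-1 ligand

A few compounds are considered here, and "the series" means these few. Any claim that something is new, unique, unknown or untested is made for them only; others in the source may bear on it.

Going by the values given here, compound 2 `COc1cc2nc(N3CCC(OCC(C)(C)OC)CC3)nc(N)c2cc1OC` gives 1.14 nM in an assay on brain for displacement of a labelled ligand from Adrenergic receptor alpha-1 (Rattus norvegicus); a lower number here means a stronger inhibitor, a higher number a weaker inhibitor; its only measured neighbour, compound 1 `CCCCOCCOC1CCN(c2nc(N)c3cc(OC)c(OC)cc3n2)CC1`, gives 1.03 nM, and the step of a 1.1-fold higher number from compound 1 to compound 2 (0.04 log units; within the scatter) leaves the two within the scatter of each other. Compound 3 `COc1cc2nc(N3CCC(OCC(C)O)CC3)nc(N)c2cc1OC` differs from compound 2 by 1-hydroxyethyl in place of 1-methoxy-1-methylethyl on a saturated chain carbon bound to an oxygen on a saturated carbon. Among the compounds with values here, the one step at hand, on the same saturated chain carbon bound to an oxygen on a saturated carbon, barely moved this assay, so compound 3 is expected to show a step no larger than that, a 1.3-fold higher number from compound 2 to compound 3 (0.12 log units; within the scatter). Compound 3 is therefore estimated at 1.5 nM, between 0.5 nM and 5 nM.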

Compound 3, inhibition constant: 3.52 nM
The estimate for compound 3 lay 2.3-fold (0.37 log units) below the measured number; measured number inside the range.
By their numbers in this assay, from the lowest: compounds 1 and 2 (each within the scatter of the next); then compound 3.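

Unlike the earlier step, this one shows that the saturated chain carbon bound to an oxygen does respond to its substituent: 1-hydroxyethyl gives a clear shift against both 1-methoxy-1-methylethyl (a 3.1-fold higher number from compound 2 to compound 3 (0.49 log units; beyond the scatter)) and butoxymethyl (a 3.4-fold higher number from compound 1 to compound 3 (0.53 log units; beyond the scatter)). The entering group has fewer heavy atoms and adds a hydrogen-bond donor, so these two differences travel together. Nothing measured here accounts for the shift.

Going by these compounds, whether the hydroxyl or the shorter chain carries the step stays open. So does how an amine or a longer hydroxyalkyl chain would read at this place.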